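Piperidin-1-yl in place of methoxy in compound 3

The compounds below may be only part of what the source reports. "The series", "measured", "known", "first", "only" and "open" are said of these compounds alone.

Readings so far in an ADME assay on Huh7.5.1 cells (Homo sapiens) for cytotoxicity, read by WST assay, with a stated time of 48 h (on this read-out higher numbers stand for lower toxicity in this test and lower numbers for higher toxicity in this test), are these:

- Compound 1 `Cc1c(-c2ccc(Cc3ccc(S(=O)(=O)C(F)(F)F)cc3)cc2)[nH]c2cccc(F)c2c1=O` gives > 2500 nM as a limit.
- Compound 2 `Cc1c(-c2ccc(Cc3ccc(S(F)(F)(F)(F)F)cc3)cc2)[nH]c2cccc(F)c2c1=O` gives > 5000 nM as a limit.
- Compound 3 `COc1ccc(Cc2ccc(-c3[nH]c4cccc(F)c4c(=O)c3C)cc2)cc1` gives > 10000 nM as a limit.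

Compound 3 stands only at the limit > 10000 nM and no number is known for it. The other two readings are limits as well, so the series offers no measured number to build on.

Compound 4 `Cc1c(-c2ccc(Cc3ccc(N4CCCCC4)cc3)cc2)[nH]c2cccc(F)c2c1=O` carries piperidin-1-yl in place of methoxy on an aromatic carbon.

Going by the values given here, three measured steps bear on this change, as each exchanges the group at that same place: a step that the two limits leave unreadable from compound 1 to compound 3 and a step that the two limits leave unreadable from compound 2 to compound 3 and a step that the two limits leave unreadable from compound 1 to compound 2 in turn. None of them has a readable size or direction, so they support no expectation of a definite shift in this assay and only a loose estimate can be given. The expected change is an at least 1.4-fold lower number from compound 3 to compound 4 (0.15 log units; that floor lies within the scatter) and it should be read as weakly founded. Compound 4 may well be reported as a limit too. For compound 4 the estimated value is 7000 nM with an expected range from 2500 nM to 15000 nM in this test.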

Compound 4, half-maximal cytotoxic concentration: > 10000 nM
Compound 4: only a limit was reported; the forecaster's own chance of this, stated with the estimate: 70%; middle value at least 1.4-fold (0.15 log units) away from the limit.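

In this assay compound 4 gives > 10000 nM, which is a limit and not a number. None of the steps to compound 4 from compound 1, compound 2 or compound 3 can be read. The compounds shown leave open whether exchanging the group on that aromatic carbon changes this read-out at all.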